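Swapping an Aryl Amide for Acetyl: Expected Inhibition

The source may hold more compounds than are shown below. What is called first, only, known or untested is meant among the compounds shown, and "the series" means these compounds.

Three compounds sharing one core were measured in an assay on isolated protein for inhibition of aldehyde dehydrogenase 1A1 (Homo sapiens), read by spectrophotometry, tested at 10 uM; on this read-out lower numbers stand for less inhibition and higher numbers for more inhibition at the one concentration tested (going by the name of the read-out). Compound 1 `Cc1cccc(Cn2c(CN3CCN(C(=O)c4ccc(Cl)cc4)CC3)nc3ccccc32)c1` gives 23.2%, compound 2 `Cc1cccc(Cn2c(CN3CCN(C(=O)CC(C)C)CC3)nc3ccccc32)c1` gives 71.4%, and compound 3 `Cc1cccc(Cn2c(CN3CCN(C(=O)c4ccc(F)cc4)CC3)nc3ccccc32)c1` gives 27.1%. Compound 3 thus stands second highest of the three: its value sits within the scatter of compound 1, while compound 2 lies well beyond it.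

Compound 4 `CC(=O)N1CCN(Cc2nc3ccccc3n2Cc2cccc(C)c2)CC1` has not yet been measured. It differs from compound 3 as follows: methyl in place of 4-fluorophenyl on a carbonyl carbon.

Among the measured compounds shown here, two measured steps bear on this change, both exchanging an aromatic group on the carbonyl carbon for a small alkyl group or the reverse. The step of a number 48.2 percentage points higher from compound 1 to compound 2 (beyond the scatter) and the step of a number 44.3 percentage points lower from compound 2 to compound 3 (beyond the scatter) were both large. Both point the same way: a small alkyl group on that carbonyl gives more inhibition than an aryl group. A methyl is also a small alkyl group, so a large rise in this assay is expected, though its size is uncertain because only compound 2 with 71.4% shows an alkyl example. The expected step is a number 27.9 percentage points higher from compound 3 to compound 4 (beyond the scatter). Compound 4 is therefore estimated at 55%, between 30% and 78%.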

Compound 4, a percentage reported as inhibition, at one concentration (the size of the read-out at that concentration, not a potency): 70.3%
Compound 4: middle estimate off by 15.3 percentage points, on the low side; the measured number falls inside the stated range.
By their numbers in this assay, from the lowest: compounds 1 and 3 (each within the scatter of the next); then compounds 4 and 2 (each within the scatter of the next).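

In this assay, an acetyl in place of either aryl amide gives a large step (a number 43.2 percentage points higher from compound 3 to compound 4 (beyond the scatter); a number 47.1 percentage points higher from compound 1 to compound 4 (beyond the scatter)), so the high inhibition of compound 2 does not depend on the isobutyl group alone. Shortening that chain leaves the read-out within the scatter (a number 1.1 percentage points lower from compound 2 to compound 4 (within the scatter)), so at this carbonyl carbon, methyl and isobutyl cannot be told apart, while both stand well clear of the two aryl groups. No measurement here explains this difference.

As far as these compounds go, whether the aromatic ring itself goes with the low inhibition remains open, and a cyclohexyl group on the carbonyl carbon would test that directly. From the compounds shown here alone, how far the alkyl side extends is also open, as a longer chain or an amine at this place could behave differently.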